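The compounds below may be only part of what the source reports. "The series", "measured", "known", "first", "only" and "open" are said of these compounds alone.

Working notes on the amide series sharing the core of compound 1 `COc1ccc2c(=O)c(/C=C/C(=O)Nc3cccc(Cl)c3)coc2c1`.

In a functional assay (QGY7701 cells, Homo sapiens) for inhibition, read by MTT assay, with a stated time of 48 h (on this read-out lower numbers stand for stronger inhibition and higher numbers for weaker inhibition), compound 1 reaches only the assay limit of > 100000 nM. Compound 2 `COc1ccc2c(=O)c(/C=C/C(=O)Nc3ccccc3)coc2c1` gives 14000 nM in this assay. Compound 3 `COc1ccc2c(=O)c(/C=C/C(=O)Nc3ccccc3Cl)coc2c1` gives 23000 nM in this assay, the highest of the two numbers, with compound 2 nearest at a separation within the scatter.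

The measured steps among these three are an at least 7.1-fold lower number from compound 1 to compound 2 (0.85 log units; beyond the scatter), an at least 4.3-fold lower number from compound 1 to compound 3 (0.63 log units; beyond the scatter) and a 1.6-fold higher number from compound 2 to compound 3 (0.22 log units; within the scatter).

Compound 4 `COc1ccc2c(=O)c(/C=C/C(=O)Nc3cc(C)ccc3C)coc2c1` is not yet measured. Against compound 3 the change is 2,5-dimethylphenyl in place of 2-chlorophenyl on an amide-type nitrogen. The step that bears most directly is a 1.6-fold higher number from compound 2 to compound 3 (0.22 log units; within the scatter), which shows that chloro in place of hydrogen on the aromatic carbon changes little. The step of an at least 4.3-fold lower number from compound 1 to compound 3 (0.63 log units; beyond the scatter) shows that moving the single substituent on that ring matters at least modestly, and compound 4 carries a second substituent on the ring, so the outcome is less certain.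

Compound 4 is expected to give about 28000 nM in this assay, between 8000 nM and 100000 nM, which would be a step of a 1.2-fold higher number from compound 3 to compound 4 (0.09 log units; within the scatter), with a real chance that only a limit is returned.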

Compound 4, half-maximal inhibitory concentration: > 100000 nM
Compound 4 gave a limit, no number; the forecaster's own chance of this, stated with the estimate: 25%; middle value at least 3.5-fold (0.55 log units) away from the limit.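

On the amide-type nitrogen, 2,5-dimethylphenyl in place of 2-chlorophenyl gives an at least 4.3-fold higher number from compound 3 to compound 4 (0.63 log units; beyond the scatter), and 2,5-dimethylphenyl in place of phenyl gives an at least 7.1-fold higher number from compound 2 to compound 4 (0.85 log units; beyond the scatter). The earlier compounds shown here showed that this ring accepts 2-chlorophenyl with no change beyond the scatter from phenyl, whereas compound 4 shows that 2,5-dimethylphenyl, like 3-chlorophenyl in compound 1, falls out of the measurable range of this assay, so tolerance at this position does not extend to every substituted ring. The step between compound 1 and compound 4 cannot be read, since both stand at a limit and not at a number: the limit of > 100000 nM in this assay, at which 2 of the 4 values shown sit.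

The compounds shown do not separate the effect of the two methyl groups as such from that of carrying a second substituent on the ring, and a ring with a single methyl group would bear on that question. On these data alone, it also remains open how an amine or a carboxylic acid on this ring would read, and whether any group here can give a number beyond the scatter lower than that of compound 2.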